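A few compounds are considered here, and "the series" means these few. Any claim that something is new, unique, unknown or untested is made for them only; others in the source may bear on it.

Working notes on the series.

The shared core is that of compound 1 `O=C1C=CC(=O)c2ncncc21`, which carries nothing on it and in a functional assay on MIA PaCa-2 cells (Homo sapiens) for cytotoxicity, read by MTT assay, with a stated time of 72 h (on this read-out lower numbers stand for stronger inhibition and higher numbers for weaker inhibition), gives 9400 nM. Compound 2 `NC(=O)c1ccc(NC2=CC(=O)c3ncncc3C2=O)cc1` bears an anilino group with a carbamoyl on the aryl ring, and in this assay compound 2 gives 8000 nM, a number that sits within the scatter of compound 1, so the two are not told apart by these data. Compound 3 `O=C1C(NCc2ccc(F)cc2)=CC(=O)c2ncncc21`, with a benzylamino substituent on the core, in this assay gives 1700 nM, a lower number than compound 2 by a gap that lies beyond the scatter. Going by the values given here, on the three numbers so far compound 2 therefore stands among the weaker pair, with compound 3 alone clearly below it.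

Compound 4 `Nc1ccc(-c2ccc(NC3=CC(=O)c4ncncc4C3=O)cc2)cc1` is not yet measured. It differs from compound 2 by 4-aminophenyl in place of carbamoyl on an aromatic carbon. The difference sits on an aromatic carbon of a six-membered aromatic ring of carbon only, para to a large group.

Among the compounds with values here, no measured pair reflects this change, so the expectation rests on compound 3, whose value of 1700 nM shows that a larger group on the amine side can go with a lower number. Compound 4 is expected to give 4000 nM, with a range from 1500 nM to 10000 nM. The expected step is a 2.0-fold lower number from compound 2 to compound 4 (0.30 log units; within the scatter), a modest decrease near the edge of the scatter.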

Compound 4, half-maximal inhibitory concentration: 2500 nM
Estimate against measurement, compound 4: 1.6-fold (0.20 log units) above; low and high end bracket the measured number.
By their numbers in this assay, from the lowest: compounds 3 and 4 (each within the scatter of the next); then compounds 2 and 1 (each within the scatter of the next).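

Going by these compounds alone, replacing carbamoyl with 4-aminophenyl on this aromatic carbon, para to a large group, gives the first single-place comparison: in this assay the change brings a 3.2-fold lower number from compound 2 to compound 4 (0.51 log units; beyond the scatter), so the number responds to what sits at this position. The entering group is the larger one and adds a six-membered aromatic ring of carbon only, while the hydrogen-bond donor and acceptor counts of the two groups are the same. No measurement at hand bears on the reason for this step.

Going by these compounds, whether the lower number goes with the added aromatic ring or with the amine on it stays open, and a plain phenyl group at the same carbon would separate the two. Also open, on these data alone, is how a carboxylic acid or a longer chain would read at this position.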